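From amino to methoxy in a growth inhibition series

A few compounds are considered here, and "the series" means these few. Any claim that something is new, unique, unknown or untested is made for them only; others in the source may bear on it.

In a functional assay on OVCAR cells (Homo sapiens) for inhibition, read by MTT assay, with a stated time of 48 h (a lower number here means a stronger inhibitor of growth, a higher number a weaker inhibitor of growth), compound 1 (`O=[N+]([O-])c1cccc(-c2cc(-c3ccccc3)n[nH]2)c1`) gives (5800 nM). In the same test compound 2 (`Nc1ccc(-c2cc(-c3ccc(C(F)(F)F)cc3)n[nH]2)cc1`) gives (18600 nM). Going by the values given here, compound 2 thus holds the higher of the two numbers so far, and its gap to compound 1 lies beyond the scatter. These two compounds differ in more than one place, however, so their gap cannot be assigned to any single group. Among the compounds with values here, no measured pair yet isolates one structural change.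

Compound 3 (`COc1ccc(-c2cc(-c3ccc(C(F)(F)F)cc3)n[nH]2)cc1`) keeps the rest of compound 2 but carries methoxy in place of amino on an aromatic carbon, para to a large group (methoxy in place of amino on an aromatic carbon). Within the data shown here, with no measured step to guide it, the expectation in this assay starts from compound 2 at (18600 nM) and allows for no shift beyond the scatter. The expected step is small (a 1.3-fold lower number from compound 2 to compound 3 (0.12 log units; within the scatter)), with only a slight lean towards a lower number. Compound 3 is estimated at (14000 nM), with an expected range from (5000 nM) to (40000 nM).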

Compound 3, concentration for 50% growth inhibition: 22800 nM
Compound 3: the middle estimate sits 1.6-fold (0.21 log units) below what was measured, within the range that was stated.
By their numbers in this assay, from the lowest: compound 1; then compounds 2 and 3 (each within the scatter of the next).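

In this assay, going by these compounds alone, compound 2 and compound 3 form the first pair that isolates a single structural change, and methoxy in place of amino on an aromatic carbon, para to a large group, gives a step within the scatter (a 1.2-fold higher number from compound 2 to compound 3 (0.09 log units; within the scatter)). Amino has a hydrogen-bond donor and methoxy has none, yet the two compounds cannot be told apart in this growth inhibition read-out, so this one pair shows no sign that the test separates these two groups at this place. Nothing available here explains this result, and the pair alone cannot say why the two compounds read alike.

The compounds shown leave open whether a hydroxy group, a carboxylic acid or a longer chain such as ethoxy at the same place would also stay within the scatter of compound 2, since one exchange cannot define what this position tolerates. They also leave open which structural difference lies behind the separate standing of compound 1, as no measured pair links it to compound 2 or compound 3 through a single change.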